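Sulfonyl in Place of Carbamoyl on the Ring Nitrogen

The compounds below may be only part of what the source reports. "The series", "measured", "known", "first", "only" and "open" are said of these compounds alone.

Compound 1 `C=CCNC(=O)n1c(-c2ccc(OC)cc2)cc(=O)c2c(OC)cc(OC)cc21` was tested in a functional assay on SUP-B15 cells (Homo sapiens) for antiproliferative activity, with a stated time of 72 h (on this read-out higher numbers stand for an effect only at larger amounts of compound and lower numbers for an effect already at smaller amounts), and gives 16000 nM. Compound 2 `COc1ccc(-c2[nH]c3cc(OC)cc(OC)c3c(=O)c2I)cc1`, which differs from compound 1 in more than one place, was run in the same assay; for compound 2 only a limit of > 86200 nM is reported, not a number. For the measured compounds named here, compound 1 thus stands as the only compound with a measured number in this assay, the other value shown being (the limit of > 86200 nM in this assay, at which 1 of the 2 values shown sits). Compound 3 `COc1ccc(-c2cc(=O)c3c(OC)cc(OC)cc3n2S(=O)(=O)c2ccc(Br)cc2)cc1` has not been measured. It differs from compound 1 by (4-bromophenyl)sulfonyl in place of allylcarbamoyl on an aromatic nitrogen. Going by the values given here, no step between measured compounds that differ in a single place is available, so the size of this change cannot be read from any neighbour. Among the compounds with values here, compound 1 itself sits at a high concentration in this assay, and nothing among the measured compounds points to a gain from this change. The step is therefore expected to be a 1.4-fold higher number from compound 1 to compound 3 (0.14 log units; within the scatter), a loss of modest size or none beyond the scatter. Compound 3 is estimated to give 22000 nM, with a range from 6000 nM to 80000 nM.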

Compound 3, half-maximal effective concentration: 63800 nM
The estimate for compound 3 lay 2.9-fold (0.46 log units) below the measured number; measured number inside the range.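

In this assay, for the compounds shown here, the exchange of allylcarbamoyl for (4-bromophenyl)sulfonyl on the aromatic nitrogen gives a 4.0-fold higher number from compound 1 to compound 3 (0.60 log units; beyond the scatter), the first step that can be read at this position, and it shows that this change costs activity beyond the usual scatter rather than leaving it unchanged. The entering group brings a six-membered aromatic ring and no hydrogen-bond donor, whereas allylcarbamoyl has no ring and one donor, but this single step cannot separate these differences from one another. Compound 2 offers no step at this position, and for it only a limit is reported: the limit of > 86200 nM in this assay, at which 1 of the 3 values shown sits.

The compounds shown leave open whether the loss goes with the sulfonyl link itself or with the 4-bromophenyl group, a question that a methylsulfonyl group or an unsubstituted phenylsulfonyl group on the same nitrogen would address. In this assay compound 1 gives 16000 nM. The compounds shown also leave open whether a carbamoyl group carrying a longer chain, a terminal amine or a carboxylic acid in place of the allyl group would lower that number.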